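Repositioning the second fluorine on the aryl piperazine

A few compounds are considered here, and "the series" means these few. Any claim that something is new, unique, unknown or untested is made for them only; others in the source may bear on it.

The series shares one core, carrying an aryl piperazine whose aryl group varies. In a functional assay on CHO cells with adenosine receptor A1 (Homo sapiens) as the target, read by cAMP accumulation and immunoassay, with a stated time of 6 min, tested at 0.1 uM (on this read-out lower numbers stand for a stronger effect and higher numbers for a weaker effect at the one concentration tested), compound 1 `COc1ccc(N2CCN(Cc3csc(N)c3C(=O)c3ccc(Cl)cc3)CC2)cc1` gives 0%, and compound 2 `Nc1scc(CN2CCN(c3ccc(F)cc3F)CC2)c1C(=O)c1ccc(Cl)cc1` gives -17%. Within the data shown here, the one measured step, a number 17 percentage points lower from compound 1 to compound 2 (beyond the scatter), puts compound 2 lowest of the two numbers, with compound 1 as its only neighbour.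

Compound 3 `Nc1scc(CN2CCN(c3c(F)cccc3F)CC2)c1C(=O)c1ccc(Cl)cc1` differs from compound 2 by 2,6-difluorophenyl in place of 2,4-difluorophenyl on an amine nitrogen in a ring. Among the measured compounds shown here, no measured step addresses this rearrangement of the two fluorines: the step from compound 1 to compound 2 swaps a whole substituent rather than moving one within it, so it bears only loosely on the change, and it was modest in size. With the same atoms retained and only their arrangement on the ring altered, the expected step of a number 7 percentage points higher from compound 2 to compound 3 (within the scatter) is one that may not clear the scatter, with a wide range allowed in either direction.

Compound 3 is therefore estimated at -10% in this assay, between -35% and 15%.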

Compound 3, a percentage reported as activity, at one concentration (the size of the read-out at that concentration, not a potency): -23%
For compound 3 the middle estimate is 13 percentage points above the measured one; the range from low to high includes it.
By their numbers in this assay, from the lowest: compounds 3 and 2 (each within the scatter of the next); then compound 1.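

In this assay, moving the second fluorine gives a number 6 percentage points lower from compound 2 to compound 3 (within the scatter), so 2,4-difluorophenyl and 2,6-difluorophenyl on the amine nitrogen in the ring cannot be told apart on this read-out. The replacement of 4-methoxyphenyl now holds for a second difluorophenyl group, with a number 23 percentage points lower from compound 1 to compound 3 (beyond the scatter), so both fluorine arrangements stand apart from compound 1 beyond the scatter. Nothing available gives a cause for these numbers.

Open, as far as these compounds go, is whether an unsubstituted phenyl or a phenyl carrying one fluorine on the same nitrogen would group with compound 2 and compound 3 or with compound 1. Also open, from the compounds shown here alone, is whether chlorine in place of the two fluorines, or a pyridine in place of the phenyl, would keep the numbers of the difluorophenyl pair.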